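A methyl for a bromo: what compound 3 may show

A few compounds are considered here, and "the series" means these few. Any claim that something is new, unique, unknown or untested is made for them only; others in the source may bear on it.

In a functional assay on HeLa cells (Homo sapiens) for inhibition, read by MTT assay (a lower number here means a stronger inhibitor, a higher number a weaker inhibitor), compound 1 (`COc1ccc(/C=N/NC(=S)N/N=C2\C(=O)Nc3ccc(Br)cc32)cc1O`) gives 2220 nM. Compound 2 (`O=C1Nc2ccc(Br)cc2/C1=N/NC(=S)N/N=C/c1ccc2ccccc2c1`) reaches only the limit of > 50000 nM, so no number is known for it. Where it stands is told by the limit of > 50000 nM in this assay, at which 1 of the 2 values shown sits. Compound 3 (`Cc1ccc2c(c1)/C(=N/NC(=S)N/N=C/c1ccc3ccccc3c1)C(=O)N2`) differs from compound 2 by methyl in place of bromo on an aromatic carbon. Among the compounds with values here, since no measured pair shows what this change does, the step is expected to stay within the scatter, and compound 3 is estimated at 50000 nM, between 15000 nM and 150000 nM. The expected step of a number no higher from compound 2 to compound 3 (the limit leaves the size open) is thus none beyond the scatter.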

Compound 3, half-maximal inhibitory concentration: > 50000 nM
Compound 3 ended at the assay's limit; the forecaster's own chance of this, stated with the estimate: 70%; the middle value lies on the limit itself.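

Compound 2 and compound 3 both end at a limit in this assay, so no step between them can be read: the limit of > 50000 nM in this assay, at which 2 of the 3 values shown sit.

Going by these compounds, what methyl in place of bromo does remains open, as does the true potency of either compound.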